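Dropping the amino group: what happens to plasma protein binding

This account rests on a few compounds, and the source may have more. Where it says the series, first, only, none or still open, it means among the compounds named here.

Measured compounds:
compound 1, `Nc1nccc(N2CC[C@H](NC(=O)Nc3ccc(Cl)c(C(F)(F)F)c3)C2)n1`: 99.5%
compound 2, `CNc1nccc(N2CC[C@H](NC(=O)Nc3ccc(C)c(Cl)c3)C2)n1`: 99.3%

For the measured compounds named here, in an ADME assay on a cell-free system (plasma, Homo sapiens) for protein binding, compound 1 gives 99.5%, the lowest unbound fraction of the two compounds measured so far. Its nearest neighbour is compound 2, which in this assay gives 99.3%; the two values sit within the scatter of each other, so nothing separates them with confidence.

Compound 3, `O=C(Nc1ccc(Cl)c(C(F)(F)F)c1)N[C@H]1CCN(c2ccncn2)C1`, differs from compound 1 in one place: hydrogen in place of amino on an aromatic carbon. Going by the values given here, no pair of measured compounds shows this change, so no measured step guides the expectation. Both measured compounds sit very close to the top of the scale, which leaves little room for movement. The step a 1.3-fold lower unbound fraction from compound 1 to compound 3 (0.10 log units; within the scatter) is therefore expected to be small and to stay within the scatter, if anything toward slightly higher binding.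

For compound 3 the expected value in this assay is 99.6%, with a range from 99% to 99.9%.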

Compound 3, plasma protein binding: 99.3%
Compound 3: the middle estimate sits 1.8-fold (0.24 log units) (unbound fraction) below what was measured; the range from low to high includes it.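

For the compounds shown here, with compound 3, the amino group on the aromatic carbon between the two ring nitrogen atoms is gone for the first time, and the change from 2-aminopyrimidin-4-yl to pyrimidin-4-yl gives a 1.4-fold higher unbound fraction from compound 1 to compound 3 (0.15 log units; within the scatter) in this assay. Binding in compound 3 therefore remains close to the top of the scale at 99.3% without this amino group, so the high binding seen in compound 1 does not depend on it. Nothing shown explains why this position tolerates the loss.

Going by these compounds, whether a larger or charged group at this position, such as a carboxylic acid or a morpholine, would bring the unbound fraction up remains open. The methylamino group of compound 2 cannot settle this, as that compound differs from compound 1 in more than one place.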